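Amide series: adding a third fluoro to the aromatic ring

The compounds below may be only part of what the source reports. "The series", "measured", "known", "first", "only" and "open" are said of these compounds alone.

Measured in an assay on V79 cells for inhibition of cytochrome P450 11B1, mitochondrial (Homo sapiens), tested at 500 nM; on this read-out higher numbers stand for more inhibition at the one concentration tested (going by the name of the read-out) and lower numbers for less inhibition:
compound 1 `O=C(Nc1cccnc1)c1ccncc1`: 4%
compound 2 `O=C(Nc1cccnc1)c1ccc(F)c(F)c1`: 6%

Compound 2 gives a number within the scatter of compound 1, so the two are not separated, and both show little inhibition. Compound 3 `O=C(Nc1cccnc1)c1cc(F)c(F)cc1F` differs from compound 2 in one place: fluoro in place of hydrogen on an aromatic carbon. Within the data shown here, no measured pair isolates this change, so nothing anchors its size. Because compound 2 gives 6% and compound 1 gives 4%, both low, the step to compound 3 is expected to stay within the scatter, at an estimated a number 2 percentage points higher from compound 2 to compound 3 (within the scatter). The estimate for compound 3 in this assay is 8%, with a range from 0% to 20%.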

Compound 3, a percentage reported as inhibition, at one concentration (the size of the read-out at that concentration, not a potency): 2%
Beside the measured number, compound 3's estimate is 6 percentage points above it; the measured number falls inside the stated range.
By their numbers in this assay, from the lowest: compounds 3, 1 and 2 (each within the scatter of the next).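

Fluoro in place of hydrogen on this aromatic carbon, ortho to a group of 9 heavy atoms, gives a number 4 percentage points lower from compound 2 to compound 3 (within the scatter) in this assay. This first measured step for the change leaves compound 3 unseparated from compound 2, so the added fluoro brings no measurable gain in inhibition at the one concentration tested. Nothing available bears on the reason for this result.

From the compounds shown here alone, whether a chloro, methoxy or amino group at this position would give a step beyond the scatter stays open. So does whether any replacement of the amide linker would lift the numbers.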